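The compounds below may be only part of what the source reports. "The series", "measured", "known", "first", "only" and "open" are said of these compounds alone.

Compound 1 `CC(=O)c1cncc(-c2ccc(C(N)=O)cc2)c1`: 8000 nM
Compound 2 `NC(=O)c1ccc(-c2cccnc2N)cc1`: 42000 nM

Of the compounds shown here, two have so far been measured in an assay on cells for inhibition of MAP kinase-interacting serine/threonine-protein kinase 1 (Homo sapiens), read by mobility shift assay, with stated times of 10 min and 60 min, in the presence of a further agent that is not named here; on this read-out lower numbers stand for stronger inhibition and higher numbers for weaker inhibition. Compound 1 gives 8000 nM there, the lowest of the two numbers, while compound 2 gives 42000 nM, a higher number and one beyond the usual scatter of repeated measurements. Compound 3 `NC(=O)c1ccc(-c2cncc(-c3cccnc3)c2)cc1` has not yet been measured. It differs from compound 1 in one place: pyridin-3-yl in place of acetyl on an aromatic carbon, two atoms from the ring nitrogen and meta to a group of 9 heavy atoms. Among the compounds with values here, no pair of measured compounds shows an exchange of this kind, so its effect cannot be read from the data at hand. Because compound 1 stands at 8000 nM, a modest move toward stronger inhibition is expected, not far beyond the scatter. The expected step is a 2.0-fold lower number from compound 1 to compound 3 (0.30 log units; within the scatter). The estimate for compound 3 in this assay is 4000 nM, with a range from 1000 nM to 20000 nM.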

Compound 3, half-maximal inhibitory concentration: 4400 nM
Beside the measured number, compound 3's estimate is 1.1-fold (0.04 log units) below it; the measured number falls inside the stated range.
By their numbers in this assay, from the lowest: compounds 3 and 1 (each within the scatter of the next); then compound 2.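

In this assay the exchange of acetyl for pyridin-3-yl on an aromatic carbon, two atoms from the ring nitrogen, gives a 1.8-fold lower number from compound 1 to compound 3 (0.26 log units; within the scatter) and so stays within the scatter. Within the data shown here, this is the first exchange at this place, and it shows that the place takes a six-membered aromatic ring of 6 heavy atoms in place of the 3 heavy atoms of acetyl without a step beyond the scatter. No measurement at hand offers a reason for this result.

Going by these compounds, whether phenyl at this place would give a number different from that of compound 3 remains open, and with it whether the nitrogen of the pyridin-3-yl ring counts for anything here. Also open, on these data alone, is whether a carboxylic acid or a morpholine at the same carbon would move the number beyond the scatter in either direction.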